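Oxime ether variation: from cyclohexyl to pyrrolidinylpropyl

This account rests on a few compounds, and the source may have more. Where it says the series, first, only, none or still open, it means among the compounds named here.

Compound 2 `Nc1ncnc(Oc2ccc(NC(=O)C3(C(=O)Nc4ccc(F)cc4)CC3)cc2F)c1/C=N/OC1CCCCC1` stands at the top of the two numbers measured in a physicochemical assay for lipophilicity, using the shake flask method (a higher number here means a more lipophilic compound, a lower number a more polar compound), where compound 2 gives 4.69. Its nearest neighbour is compound 1 `Nc1ncnc(Oc2ccc(NC(=O)C3(C(=O)Nc4ccc(F)cc4)CC3)cc2F)c1/C=N/OCCO`, which in this assay gives 2.37; the step of a number 2.32 log units higher from compound 1 to compound 2 (beyond the scatter) is large and beyond the scatter. Compound 3 `Nc1ncnc(Oc2ccc(NC(=O)C3(C(=O)Nc4ccc(F)cc4)CC3)cc2F)c1/C=N/OCCCN1CCCC1` is not yet measured. It differs from compound 2 in one place: 3-(pyrrolidin-1-yl)propyl in place of cyclohexyl on an oxygen. Going by the values given here, no measured step covers a group of this kind; the only step known, from compound 1 to compound 2, exchanged 2-hydroxyethyl for cyclohexyl and was large. Since the entering group carries a nitrogen that the leaving cyclohexyl lacks, a sizeable drop is expected in this assay, with the step of a number 2.09 log units lower from compound 2 to compound 3 (beyond the scatter) estimated as the outcome. For compound 3 the estimated value in this assay is 2.6, within a range from 1.6 to 3.6.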

Compound 3, partition coefficient: 3.82
Estimate against measurement, compound 3: 1.22 log units below, and the stated range ends below it.
By their numbers in this assay, from the lowest: compound 1; then compound 3; then compound 2.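

On the oxygen whose other neighbour is a double-bonded nitrogen, exchanging cyclohexyl for 3-(pyrrolidin-1-yl)propyl gives a number 0.87 log units lower from compound 2 to compound 3 (beyond the scatter), while (pyrrolidin-1-yl)methyl in place of hydroxy on the chain gives a number 1.45 log units higher from compound 1 to compound 3 (beyond the scatter). A group carrying a nitrogen therefore lands between the two earlier compounds in this assay, and the printed values put compound 3 closer to compound 2 than to compound 1, so a nitrogen in this group does not by itself bring the number down to the level of the 2-hydroxyethyl compound. Nothing at hand accounts for where compound 3 falls.

Going by these compounds, how much of this reading belongs to the nitrogen and how much to the chain and ring around it remains open, and a 3-cyclopentylpropyl group, with carbon in place of that nitrogen, would separate the two. Also open, on these data alone, is how a shorter chain ending in the same pyrrolidine, or a morpholine at the end of the propyl chain, would read in this assay.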